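From Methylamino to Propylamino: A Small Step Expected

The compounds below may be only part of what the source reports. "The series", "measured", "known", "first", "only" and "open" are said of these compounds alone.

Three measured compounds share one core. Compound 1 `CC1(C)CC(=O)Nc2ccc(Cl)cc21` gives 82.3% in a functional assay on MDA-MB-231 cells (Homo sapiens) for cytotoxicity, read by MTT assay, with a stated time of 72 h, tested at 1 uM, in the absence of a further agent (on this read-out lower numbers stand for a stronger effect and higher numbers for a weaker effect at the one concentration tested), compound 2 `CC1(C)CC(=S)Nc2ccc(Cl)cc21` gives 85.7% in this assay, and compound 3 `CNC1=Nc2ccc(Cl)cc2C(C)(C)C1` gives 91.9%. Compound 3 has the highest of the three numbers, yet the other two lie within the usual scatter of it, so the three cannot be told apart on these data. Compound 4 `CCCNC1=Nc2ccc(Cl)cc2C(C)(C)C1` has not yet been measured. It differs from compound 3 in one place: ethyl in place of hydrogen on a saturated chain carbon bound to an amine nitrogen. Going by the values given here, no pair of measured compounds shows what such a change does, so the size of the step cannot be read from the numbers at hand. The expected step of a number 3.9 percentage points lower from compound 3 to compound 4 (within the scatter) is none beyond the scatter. Compound 4 is therefore estimated at 88%, within a range from 74% to 100%.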

Compound 4, a percentage reported as activity, at one concentration (the size of the read-out at that concentration, not a potency): 90.7%
The estimate for compound 4 lay 2.7 percentage points below the measured number; the measured number falls inside the stated range.
By their numbers in this assay, from the lowest: compounds 1, 2, 4 and 3 (each within the scatter of the next).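

Going by these compounds alone, this is the first measured step at this place: the change from methylamino to propylamino gives a number 1.2 percentage points lower from compound 3 to compound 4 (within the scatter) in this assay. Ethyl in place of hydrogen on a saturated chain carbon bound to an amine nitrogen therefore does not separate the two compounds at the one concentration tested. Nothing measured here offers an explanation for this result. Open, as far as these compounds go, is whether a longer chain such as hexyl, a phenyl ring, or a chain ending in an amine at this place would give a step beyond the scatter.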